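Working notes on four compounds of one series

The compounds below may be only part of what the source reports. "The series", "measured", "known", "first", "only" and "open" are said of these compounds alone.

The series shares a core carrying a substituted nitrogen on an aromatic ring. Compound 1 `CCOc1ccccc1-c1ccc(-c2nc3cnccc3c(NC(C(N)=O)C3CC3)c2C#N)cc1` gives 3 in a physicochemical assay for lipophilicity, read by HPLC, at pH 7.5; a higher number here means a more lipophilic compound, a lower number a more polar compound. Compound 2 `CCOc1ccccc1-c1ccc(-c2nc3cnccc3c(N[C@@H]3CCOC3=O)c2C#N)cc1` gives 2.7 in this assay, a move of a number 0.30 log units lower from compound 1 to compound 2 (within the scatter). Compound 3 `CCOc1ccccc1-c1ccc(-c2nc3cnccc3c(N[C@H](CC(C)C)C(N)=O)c2C#N)cc1` gives 3.4 in this assay, the highest of the three numbers, with a number 0.40 log units higher from compound 1 to compound 3 (beyond the scatter) and a number 0.70 log units higher from compound 2 to compound 3 (beyond the scatter).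

Compound 4 `CCOc1ccccc1-c1ccc(-c2nc3cnccc3c(NC(CC)CNS(=O)(=O)C3CC3)c2C#N)cc1` is not yet measured. Relative to compound 3 the change is a group of 11 heavy atoms (7 carbon, 1 nitrogen, 2 oxygen, 1 sulfur; one three-membered non-aromatic ring of carbon only) in place of a group of 8 heavy atoms (6 carbon, 1 nitrogen, 1 oxygen; no ring), on a nitrogen on an aromatic ring. Going by the values given here, the steps that bear on it are those into compound 3: the swap of a three-membered ring group for an open chain gave a number 0.40 log units higher from compound 1 to compound 3 (beyond the scatter), and the swap from the five-membered ring group gave a number 0.70 log units higher from compound 2 to compound 3 (beyond the scatter). Among the compounds with values here, compound 4 brings a three-membered ring back while the replaced chain grows; no measured pair matches this exchange, so no step beyond the scatter is expected. The estimated step is no change at the digits printed from compound 3 to compound 4 (within the scatter). Compound 4 is expected at 3.4, with a range from 2.9 to 3.9.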

Compound 4, distribution coefficient: 3.6
The estimate for compound 4 lay 0.20 log units below the measured number; the measured number falls inside the stated range.
By their numbers in this assay, from the lowest: compounds 2 and 1 (each within the scatter of the next); then compounds 3 and 4 (each within the scatter of the next).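

At the nitrogen on an aromatic ring, the group of 11 heavy atoms, with its sulfur and three-membered ring, takes the place of 1-carbamoyl-3-methylbutyl with a number 0.20 log units higher from compound 3 to compound 4 (within the scatter) in this assay, so this exchange cannot be told from the scatter. The same group gives a number 0.90 log units higher from compound 2 to compound 4 (beyond the scatter) and a number 0.60 log units higher from compound 1 to compound 4 (beyond the scatter), which shows that a three-membered ring in the group does not by itself hold the number near that of compound 1. No measurement available bears on the cause of these steps.

On these data alone, whether the sulfur-bearing part, the three-membered ring or the overall size of the group sets the number in compound 4 remains open. As far as these compounds go, how a carboxylic acid or an amine on this chain would read in this assay also remains open.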